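A few compounds are considered here, and "the series" means these few. Any claim that something is new, unique, unknown or untested is made for them only; others in the source may bear on it.

Measured compounds:

- compound 1, `Cc1ccccc1-c1nc(CN2CCC(C(=O)NCCCN3CC(C)(C)CC(C)(C)C3)CC2)c(C)o1`: 0.095 h
- compound 2, `Cc1oc(-c2c(Br)cccc2Br)nc1CN1CCC(C(=O)NCCCN2C[C@H](C)C[C@H](C)C2)CC1`: 0.035 h
- compound 3, `Cc1ccccc1-c1nc(CN2CCC(C(=O)N3CCN(C4CCN(C)CC4)CC3)CC2)c(C)o1`: a limit, > 0.5 h

The three compounds share a core and were tested in an ADME assay on microsomes from liver (Rattus norvegicus) for metabolic stability, read by LC-MS, using NADPH, at 37 degrees C; a higher number here means that the compound lasts longer, a lower number that the compound disappears faster. Compound 1 gives 0.095 h in this assay. Compound 2 gives 0.035 h in this assay, the lowest of the two plain numbers; the nearest number, that of compound 1, lies higher by a gap beyond the usual scatter. For compound 3 this assay reports only a limit, > 0.5 h, and not a number (the limit of > 0.5 h in this assay, at which 1 of the 3 values shown sits).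

Compound 4, `Cc1ccc(-c2nc(CN3CCC(C(=O)NCCCN4C[C@H](C)C[C@H](C)C4)CC3)c(C)o2)c(C)c1`, has not yet been measured. It differs from compound 2 in one place: 2,4-dimethylphenyl in place of 2,6-dibromophenyl on an aromatic carbon.

Among the measured compounds shown here, no pair of measured compounds differs in this one place alone, so the data give no direct precedent for the size of this step in this assay. The two plain numbers, those of compound 1 and compound 2, differ by more than the scatter, but those two compounds differ in more than one place, so the two numbers can only be taken as they stand.

The step from compound 2 to compound 4 is expected to be small, a 1.7-fold higher number from compound 2 to compound 4 (0.23 log units; within the scatter), and may fall within the scatter. For compound 4 the half-life in this assay is estimated at 0.06 h, in a range from 0.02 h to 0.18 h.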

Compound 4, half-life: > 0.5 h
Compound 4: only a limit was reported (the forecaster's own chance of this, stated with the estimate: 5%); middle value at least 8.3-fold (0.92 log units) from the limit.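

Among the compounds shown here, replacing 2,6-dibromophenyl with 2,4-dimethylphenyl on this aromatic carbon of the five-membered ring gives an at least 14-fold higher number from compound 2 to compound 4 (1.15 log units; beyond the scatter), the first change in a single place that can be read, and it is large. Both groups have one six-membered aromatic ring of carbon only and the same number of heavy atoms, so what differs is the substituents on that ring, and this difference alone moves the half-life far beyond the scatter. Compound 4 gives only a limit in this assay, > 0.5 h, and it is not alone there: the limit of > 0.5 h in this assay, at which 2 of the 4 values shown sit.

The compounds shown leave open whether the change follows from losing the two bromine atoms, from gaining the two methyl groups or from where those groups sit on the ring, as all of these change together here; a 2,6-dimethylphenyl group or a plain phenyl group on the same scaffold would help to separate them. They also leave open what number compound 4 would give, and so the full size of this step.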